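Swapping fluoro for trifluoromethoxy on the sulfonyl ring

The source may hold more compounds than are shown below. What is called first, only, known or untested is meant among the compounds shown, and "the series" means these compounds.

Of the compounds shown here, three sharing one core have so far been tested in a functional assay on MDA-MB-231 cells (Homo sapiens) for inhibition, read by sulforhodamine B assay, tested at 10 uM; a lower number here means less inhibition, a higher number more inhibition at the concentration tested (going by the name of the read-out). Compound 1 `CN(C)c1ccc(C2CC(c3ccc(-n4cncn4)cc3)=NN2C(=O)CCCl)cc1` gives 3.7%. Compound 2 `CN(C)c1ccc(C2CC(c3ccc(-n4cncn4)cc3)=NN2C(=O)c2cc(Cl)cc(Cl)c2)cc1` gives 9.4%. Compound 3 `CN(C)c1ccc(C2CC(c3ccc(-n4cncn4)cc3)=NN2S(=O)(=O)c2ccc(F)cc2)cc1` gives 12.1%. Compound 3 carries the largest of the three numbers, but the gaps are small: a number 2.7 percentage points higher from compound 2 to compound 3 (within the scatter), a number 8.4 percentage points higher from compound 1 to compound 3 (within the scatter) and a number 5.7 percentage points higher from compound 1 to compound 2 (within the scatter), so none of the three compounds is separated from another beyond the usual scatter of this measurement.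

Compound 4 `CN(C)c1ccc(C2CC(c3ccc(-n4cncn4)cc3)=NN2S(=O)(=O)c2ccc(OC(F)(F)F)cc2)cc1` is the next compound to be measured. It differs from compound 3 in one place only: trifluoromethoxy in place of fluoro on an aromatic carbon. The three measured steps all concern the group attached to the ring nitrogen and leave the rest of the molecule unchanged; none of them touches the ring that changes here. They show only that, on this core, three rather different groups at that nitrogen gave numbers within the scatter of one another. Going by the values given here, with no step bearing directly on the change, and all measured numbers low and close together, the expected step of a number 1.9 percentage points higher from compound 3 to compound 4 (within the scatter) in this assay is small, with no direction beyond the scatter. The estimate for compound 4 is 14%, between 2% and 30%.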

Compound 4, a percentage reported as inhibition, at one concentration (the size of the read-out at that concentration, not a potency): 18.5%
Estimate against measurement, compound 4: 4.5 percentage points below; the measured number falls inside the stated range.
By their numbers in this assay, from the lowest: compounds 1, 2, 3 and 4 (each within the scatter of the next, the first and the last beyond it).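

Going by these compounds alone, this is the first measured change on the aryl ring of the sulfonyl group. In this assay, going from 4-fluorophenyl to 4-(trifluoromethoxy)phenyl gives a number 6.4 percentage points higher from compound 3 to compound 4 (within the scatter), so replacing fluoro, with its single heavy atom, by trifluoromethoxy, with five heavy atoms and one hydrogen-bond acceptor by the count, produces no step beyond the scatter at this place, para to a large group. This single pair gives no direction for the change, and no measurement shown here offers an explanation for the size of the step.

The compounds shown carry only fluoro and trifluoromethoxy on this ring, so it remains open how an amine, a carboxylic acid or a longer alkoxy chain would fare at the same place. Also open, from the compounds shown here alone, is whether trifluoromethoxy would give a similar result on an aryl ring attached through a carbonyl, as in the 3,5-dichlorophenyl group of compound 2, rather than through a sulfonyl group.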